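Swapping cyclopropyl for isopropyl on a second core

The source may hold more compounds than are shown below. What is called first, only, known or untested is meant among the compounds shown, and "the series" means these compounds.

Compound 1 `COc1cc(N(CC2CC2)c2ccc(F)c3ccccc23)cnc1C(=O)[C@H]1C[C@@H]1C(=O)O` and compound 2 `COc1cc(N(CC(C)C)c2ccc(F)c3ccccc23)cnc1C(=O)[C@H]1C[C@@H]1C(=O)O` share one core and differ only in the change (isopropyl in place of cyclopropyl on a saturated chain carbon bound to a nitrogen on an aromatic ring). In a physicochemical assay for lipophilicity, read by LC-MS, in phosphate buffer, measured as octanol-water partition, at pH 7.4 (a higher number here means a more lipophilic compound, a lower number a more polar compound), compound 1 gives 1.9, and compound 2 gives 2.2, so the step is a number 0.30 log units higher from compound 1 to compound 2 (within the scatter). Compound 3 `COc1cc(N(CC2CC2)c2cc(C(F)(F)F)ccc2F)cnc1C(=O)[C@H]1C[C@@H]1C(=O)O` carries a different core; the difference between the two cores is not broken down here. In this assay compound 3 gives 1.2. Compound 4 `COc1cc(N(CC(C)C)c2cc(C(F)(F)F)ccc2F)cnc1C(=O)[C@H]1C[C@@H]1C(=O)O` is compound 3 with the same change, (isopropyl in place of cyclopropyl on a saturated chain carbon bound to a nitrogen on an aromatic ring). Within the data shown here, a step like a number 0.30 log units higher from compound 1 to compound 2 (within the scatter) is expected again because a number 0.30 log units higher from compound 1 to compound 2 (within the scatter) is the only measured example of this change. The expected step for compound 4 is therefore a number 0.30 log units higher from compound 3 to compound 4 (within the scatter). Compound 4 is estimated at 1.5, with a range from 1.1 to 1.9.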

Compound 4, distribution coefficient: 1.4
Compound 4: middle estimate off by 0.10 log units, on the high side; the measured number falls inside the stated range.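

In this assay, the swap of cyclopropyl for isopropyl on the core of compound 3 gives a number 0.20 log units higher from compound 3 to compound 4 (within the scatter) and on the core of compound 1 gives a number 0.30 log units higher from compound 1 to compound 2 (within the scatter), so neither step stands clear of the scatter. Two pairs that both lie within the scatter do not show that this change has a real effect of a fixed size, nor that it would behave the same way on any further core. No evidence here explains either step.

The compounds shown leave open whether a longer chain, such as n-butyl, or an amine at this place would give a step beyond the scatter. They also leave open how the swap behaves on a core without the carboxylic acid.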